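From Methoxy to Trifluoromethoxy on Compound 1

The source may report more compounds than this note shows. Statements on the series, on what has been measured and on what is new or still open speak of the compounds shown alone.

Going by the values given here, in a functional assay on A549 cells (Homo sapiens) for antiproliferative activity, read by MTT assay, with a stated time of 72 h (on this read-out lower numbers stand for stronger inhibition and higher numbers for weaker inhibition), compound 1 `COc1ccc(-c2ncnn2-c2cc(OC)c(OC)c(OC)c2)cc1` gives 520 nM, the only exact number so far. Its close relative compound 2 `COc1cccc(-c2ncnn2-c2cc(OC)c(OC)c(OC)c2)c1` is reported as > 10000 nM, which is a limit of the assay and not a number.

Among the compounds with values here, the single measured step, an at least 19-fold higher number from compound 1 to compound 2 (1.28 log units; beyond the scatter), is large and beyond the scatter. It comes from putting 3-methoxyphenyl in place of 4-methoxyphenyl, so it shows that a change on this part of compound 1 can cost much of the activity.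

Compound 3 `COc1cc(-n2ncnc2-c2ccc(OC(F)(F)F)cc2)cc(OC)c1OC` keeps the core of compound 1 and alters the same group in another way: trifluoromethyl in place of methyl on an oxygen on an aromatic ring. This is methoxy to trifluoromethoxy, with the group staying where it is. Within the data shown here, the step to compound 2 therefore bears on it only loosely, and no measured step shows this exact swap. A drop as steep as an at least 19-fold higher number from compound 1 to compound 2 (1.28 log units; beyond the scatter) is not expected, though a moderate move towards a higher number seems more likely than a gain. The expected step is a 1.9-fold higher number from compound 1 to compound 3 (0.28 log units; within the scatter). Compound 3 is estimated at 1000 nM, with an expected range from 150 nM to 6000 nM.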

Compound 3, half-maximal inhibitory concentration: > 10000 nM
Compound 3 ended at the assay's limit; the forecaster's own chance of this, stated with the estimate: 15%; at least 10-fold (1.00 log units) between middle value and limit.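

Compound 3 is reported in this assay as > 10000 nM, which is a limit of the assay and not a number. Going by these compounds alone, the step, an at least 19-fold higher number from compound 1 to compound 3 (1.28 log units; beyond the scatter), shows that the oxygen-linked group of compound 1 matters even when it stays where it is: trifluoromethyl in place of methyl on an oxygen on an aromatic ring costs as much activity as this assay can show, so the earlier loss no longer stands alone as the only sensitive change at this part of the molecule. How far either change really goes cannot be read, since the true numbers of both changed compounds lie beyond what the assay reports: the limit of > 10000 nM in this assay, at which 2 of the 3 values shown sit.

The compounds shown leave open whether any other group in this place, such as an ethoxy group, a hydroxyl or an amine, would hold on to the activity of compound 1 at 520 nM or come close to it. They also leave open whether methoxy is the best choice here or simply the only group shown so far that gives an exact number.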